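This account rests on a few compounds, and the source may have more. Where it says the series, first, only, none or still open, it means among the compounds named here.

Compound 1 `COc1cccc(-n2cc3nc(-c4cccnc4C)n(C[C@H]4CCCN(Cc5ccco5)C4)c(=O)c3n2)c1`: 2.7 nM
Compound 2 `COc1cccc(-n2cc3nc(-c4cccnc4C)n(C[C@H]4CCCN(CC5CCC5)C4)c(=O)c3n2)c1`: 1.6 nM
Compound 3 `COc1cccc(-n2cc3nc(-c4cccnc4C)n(C[C@H]4CCCN(CC5CCOC5)C4)c(=O)c3n2)c1`: 60 nM

In an assay on HEK293 cells for displacement of a labelled ligand from growth hormone secretagogue receptor type 1 (Homo sapiens), with a stated time of 60 min (on this read-out lower numbers stand for stronger inhibition and higher numbers for weaker inhibition), compound 3 gives the highest number of the three measured compounds; the nearest to it is compound 1 and the furthest is compound 2. Compound 4 `COc1cccc(-n2cc3nc(-c4cccnc4C)n(C[C@H]4CCCN(CC5CCCC5)C4)c(=O)c3n2)c1` differs from compound 3 by cyclopentyl in place of oxolan-3-yl on a saturated chain carbon bound to an amine nitrogen in a ring. Going by the values given here, two measured steps bear on this change, both ending at compound 3: a 22-fold higher number from compound 1 to compound 3 (1.35 log units; beyond the scatter) and a 38-fold higher number from compound 2 to compound 3 (1.57 log units; beyond the scatter). In both cases the arrival of oxolan-3-yl went with a large rise in the number, while the step of a 1.7-fold lower number from compound 1 to compound 2 (0.23 log units; within the scatter) showed that cyclobutyl and furan-2-yl at this position give similar numbers. Compound 4 is therefore expected to show a large drop in the number, about a 24-fold lower number from compound 3 to compound 4 (1.38 log units; beyond the scatter). The reference point for this expectation is the cyclobutyl analogue, compound 2, which gives 1.6 nM. The estimate for compound 4 is 2.5 nM, with a range from 0.8 nM to 9 nM.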

Compound 4, half-maximal inhibitory concentration: 12 nM
Compound 4: middle estimate off by 4.8-fold (0.68 log units), on the low side; measured number outside the range, above it.
By their numbers in this assay, from the lowest: compounds 2 and 1 (each within the scatter of the next); then compound 4; then compound 3.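

Replacing oxolan-3-yl with cyclopentyl recovers only part of the loss (a 5.0-fold lower number from compound 3 to compound 4 (0.70 log units; beyond the scatter)), so removing the ring oxygen does not by itself restore the low numbers. This position also separates two all-carbon rings, since cyclopentyl stands clearly apart from cyclobutyl (a 7.5-fold higher number from compound 2 to compound 4 (0.88 log units; beyond the scatter)) and from furan-2-yl (a 4.4-fold higher number from compound 1 to compound 4 (0.65 log units; beyond the scatter)). No evidence at hand accounts for these shifts. The compounds shown leave open how cyclohexyl, phenyl or a piperidin-4-yl ring would read on this chain carbon.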